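This account rests on a few compounds, and the source may have more. Where it says the series, first, only, none or still open, it means among the compounds named here.

Two compounds of the series have so far been run in a functional assay on the whole organism (strain albino) for inhibition, with Rattus norvegicus as the target, read by paw edema, with a stated time of 2 h, at a dose of 0.28 mmol/kg by the oral route; a higher number here means more inhibition at the dose given (going by the name of the read-out), a lower number less inhibition. Compound 1 `CCn1c(SCC(=O)c2ccccc2)nnc1-c1ccc(OC)cc1` gives 60% in this assay. Compound 2 `C=CCn1c(SCC(=O)c2ccccc2)nnc1-c1ccc(OC)c(OC)c1` gives 63% in this assay. On the two numbers in hand compound 2 stands highest, but its nearest neighbour, compound 1, lies within the usual scatter of it, so the two cannot be told apart on these data. For the measured compounds named here, compound 1 and compound 2 differ in two places at once, and no single-change step between measured compounds is available.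

Compound 3 `C=CCn1c(SCC(=O)c2ccccc2)nnc1-c1ccc(OC)cc1` has not yet been measured. It differs from compound 2 by hydrogen in place of methoxy on an aromatic carbon. No measured pair isolates this change, so its size is not known from the numbers shown. Both measured values sit within the scatter of one another, so no step beyond the scatter is expected in this assay, in either direction. The step this estimate implies is a number 2 percentage points lower from compound 2 to compound 3 (within the scatter), expected to be small and without a clear direction. Compound 2 gives 63% and compound 1 gives 60%. Going by the values given here, the whole series so far thus sits in one band. Compound 3 is therefore expected to give about 61%, within a range of 50% to 72%.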

Compound 3, a percentage reported as inhibition, in the whole organism at one dose (the size of the read-out at that dose, not a potency): 53%
Compound 3: the middle estimate sits 8 percentage points above what was measured; the range from low to high includes it.
By their numbers in this assay, from the lowest: compounds 3, 1 and 2 (each within the scatter of the next).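

For the compounds shown here, the first single-change reading at this aromatic carbon, ortho to a methoxy group and meta to a large group, comes from hydrogen in place of methoxy in this assay, which gives a number 10 percentage points lower from compound 2 to compound 3 (within the scatter). The chain on the aromatic nitrogen can now be read on its own as well: vinyl in place of methyl on a saturated chain carbon bound to an aromatic nitrogen gives a number 7 percentage points lower from compound 1 to compound 3 (within the scatter), so at this single dose neither change can be separated from the scatter of the read-out. No supporting measurement is available to explain the size of either step.

Still open, going by these compounds, is whether a different group on this aromatic carbon, such as an amine, a hydroxyl or a carboxylic acid, would give a step beyond the scatter, since methoxy and hydrogen are the only two compared here. Also open is whether a longer chain or a benzyl group on the aromatic nitrogen would separate from the allyl and ethyl compounds, and how any of these compounds would read at other doses or times.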